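A few compounds are considered here, and "the series" means these few. Any claim that something is new, unique, unknown or untested is made for them only; others in the source may bear on it.

Measured compounds:
compound 1 `O=C(O)/C=N/OC(c1ccc(OCc2nc3cccnc3s2)cc1)C1CCCCC1`, a functional assay for inhibition of Polyunsaturated fatty acid 5-lipoxygenase (Homo sapiens) (on this read-out higher numbers stand for weaker inhibition and lower numbers for stronger inhibition), 27 nM
compound 2 `O=C(O)/C=N/OC(c1ccc(OCc2nc3ccccc3o2)cc1)C1CCCCC1`, this assay 143 nM

Among the compounds with values here, compound 2 holds the higher of the two numbers; the only step known is a 5.3-fold higher number from compound 1 to compound 2 (0.72 log units; beyond the scatter), a heteroaryl exchange on the methyl linker. Compound 3 `O=C(O)/C=N/OC(c1ccc(Oc2ccc3ccccc3n2)cc1)C1CCCCC1` differs from compound 2 by quinolin-2-yl in place of (1,3-benzoxazol-2-yl)methyl on an oxygen on an aromatic ring. Within the data shown here, no measured step covers a change of this kind, so the single known step bears on it only loosely, and no direction can be taken from it. A step of modest size in either sense within this assay is plausible; compound 3 is estimated at 80 nM (range 20 nM to 400 nM), corresponding to an expected 1.8-fold lower number from compound 2 to compound 3 (0.25 log units; within the scatter).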

Compound 3, half-maximal inhibitory concentration: 160 nM
For compound 3 the middle estimate is 2.0-fold (0.30 log units) below the measured one, within the range that was stated.
By their numbers in this assay, from the lowest: compound 1; then compounds 2 and 3 (each within the scatter of the next).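

Quinolin-2-yl on the oxygen, in place of (1,3-benzoxazol-2-yl)methyl, gives a step within the scatter (a 1.1-fold higher number from compound 2 to compound 3 (0.05 log units; within the scatter)), so at this position in this assay these two different groups read alike. The number of compound 1 stays apart from this one as well (a 5.9-fold higher number from compound 1 to compound 3 (0.77 log units; beyond the scatter)), and neither of the other two groups matches it. Nothing measured accounts for these numbers.

Open, from the compounds shown here alone, is how (quinolin-2-yl)methyl on the same oxygen would read, which would separate the ring exchange from the methyl linker. Also open, going by these compounds, is whether an amide in place of the carboxylic acid would hold these numbers.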